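Replacing the Chloro-Methoxy Aryl Group with a Catechol

A few compounds are considered here, and "the series" means these few. Any claim that something is new, unique, unknown or untested is made for them only; others in the source may bear on it.

Measured in a functional assay on KB cells (Homo sapiens) for antiproliferative activity, read by sulforhodamine B assay, with a stated time of 3 days; a lower number here means that less compound is needed, a higher number that more compound is needed for the effect:
- Compound 1 `CCC1=C(O)c2c(oc(-c3ccccc3)cc2=O)C(CC)(CC)C1=O`: > 236 uM, a limit of the assay
- Compound 2 `CCC1=C(O)c2c(oc(-c3ccc(OC)c(Cl)c3)cc2=O)C(CC)(CC)C1=O`: 24.9 uM
- Compound 3 `CCC1=C(O)c2c(oc(-c3ccc(O)c(O)c3)cc2=O)C(CC)(CC)C1=O`: not yet measured

Among the compounds with values here, compound 2 holds the only actual number so far, since the result for compound 1 is a limit. Compound 3 shares their core and carries 3,4-dihydroxyphenyl in place of 3-chloro-4-methoxyphenyl on an aromatic carbon.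

Within the data shown here, only one measured step bears on this change: an at least 9.4-fold lower number from compound 1 to compound 2 (0.97 log units; beyond the scatter). It lies beyond the scatter, and its size is known only as a bound. Among the measured compounds shown here, it shows that the 3-chloro-4-methoxyphenyl group of compound 2 gives a lower number in this assay than the phenyl group of compound 1, but no measured step shows how a 3,4-dihydroxyphenyl group compares. Compound 3 is therefore expected to keep part of that gain, not all of it, and to move to a higher number. The expected change is a 2.4-fold higher number from compound 2 to compound 3 (0.38 log units; beyond the scatter), and this expectation is uncertain. For compound 3 the estimated value is 60 uM, within an expected range of 15 uM to 220 uM.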

Compound 3, concentration for half-maximal effect: 10 uM
Estimate against measurement, compound 3: 6.0-fold (0.78 log units) above, outside the stated range (below it).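

In this assay, the 3-chloro-4-methoxyphenyl group does not mark the lowest number reached at this aromatic carbon, since 3,4-dihydroxyphenyl in its place gives a 2.5-fold lower number from compound 2 to compound 3 (0.40 log units; beyond the scatter). Measured against plain phenyl, the same group gives an at least 23-fold lower number from compound 1 to compound 3 (1.37 log units; beyond the scatter), so among these compounds a lower number than that of phenyl needs neither the chlorine nor the methoxy group, and two hydroxyl groups serve at least as well. The size of this larger step is known only as a bound, as compound 1 stands at a limit of the assay and not at a true number: the limit of > 236 uM in this assay, at which 1 of the 3 values shown sits.

The step from compound 2 to compound 3 changes both substituents on the phenyl ring at once, so the compounds shown do not tell which of the two hydroxyl groups accounts for the lower number, or whether both are needed. As far as these compounds go, it also remains open how a 4-hydroxyphenyl group with a single hydroxyl, a 3,4-dimethoxyphenyl group or an aminophenyl group would compare at this carbon.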